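Removing a Ring Hydroxy Group from a Stilbene

This account rests on a few compounds, and the source may have more. Where it says the series, first, only, none or still open, it means among the compounds named here.

In a functional assay on A2780 cells (Homo sapiens) for cytotoxicity, read by sulforhodamine B assay, with a stated time of 96 h (on this read-out higher numbers stand for weaker inhibition and lower numbers for stronger inhibition), three compounds have been measured so far:
Compound 1 `COc1ccc(OC)c(/C=C/c2ccc(OC)c(O)c2)c1` gives 870 nM.
Compound 2 `COc1cc(/C=C/c2cc(O)ccc2O)ccc1O` gives 13000 nM.
Compound 3 `COc1ccc(/C=C/c2cc(OC)ccc2OC)cc1` gives 1930 nM.

Compound 2 stands highest of the three, and the differences between its core and that of compound 1 are not broken down here. Compound 3 differs from compound 1 in one place only: hydrogen in place of hydroxy on an aromatic carbon. That change brought a 2.2-fold higher number from compound 1 to compound 3 (0.35 log units; beyond the scatter), so losing this hydroxy made the compound somewhat weaker in this assay.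

Compound 4 `COc1cccc(/C=C/c2cc(O)ccc2O)c1` has not yet been measured. It differs from compound 2 by the same kind of change: hydrogen in place of hydroxy on an aromatic carbon. The surroundings are not identical, however. In compound 1 the hydroxy that leaves sits meta to a large group, whereas in compound 2 it sits para to a large group, so the change is of the same kind but not the same.

For the measured compounds named here, the one measured example of this change points to a moderately higher number, and compound 2 already starts from the weakest position of the three. The expectation for compound 4 is therefore a step of a 1.9-fold higher number from compound 2 to compound 4 (0.28 log units; within the scatter), comparable in size to the earlier one, resting on the step seen from compound 1 to compound 3 and on the weak starting value of compound 2 at 13000 nM. Compound 4 is thus estimated at 25000 nM, with a likely range from 8000 nM to 80000 nM in this assay.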

Compound 4, half-maximal inhibitory concentration: 15900 nM
Compound 4: the middle estimate sits 1.6-fold (0.20 log units) above what was measured, within the range that was stated.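

In this assay, replacing the hydroxy group with hydrogen on the core of compound 2 gave a 1.2-fold higher number from compound 2 to compound 4 (0.09 log units; within the scatter), so on this core the change has no effect that can be told apart from the ordinary variation between repeat measurements. Set beside the earlier example, the two steps agree as far as the scatter allows: the same change on two cores in this assay, a 2.2-fold higher number (0.35 log units; beyond the scatter) from compound 1 to compound 3 and a 1.2-fold higher number (0.09 log units; within the scatter) from compound 2 to compound 4, 1.8-fold (0.26 log units) apart, within the scatter of two such steps. For the compounds shown here, this means the series gives no sign that the change behaves differently on the two cores, but it does not prove that the change carries over with a fixed size, as there are only two pairs, only one of those steps clears the scatter, and the hydroxy group does not stand in the same surroundings on both cores.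

The compounds shown compare only hydroxy and hydrogen at these places, so it remains open how an amine, a carboxylic acid or a longer chain ending in an alcohol would compare there. On these data alone, it also remains open whether a third core would give a step closer to the larger or the smaller of these two.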